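From propanoyl to methylsulfonyl on the ring nitrogen

The compounds below may be only part of what the source reports. "The series", "measured", "known", "first", "only" and "open" are said of these compounds alone.

In an ADME assay on HEK293 cells (Homo sapiens) for cytotoxicity (on this read-out higher numbers stand for weaker inhibition and lower numbers for stronger inhibition), compound 1 (`CCC(=O)N1C[C@H](NC(=O)c2ccc(-n3ccccc3=O)cc2)[C@H](NC(=O)c2ccc(Cl)s2)C1`) gives > 100000 nM as a limit, not a number. Compound 2 (`O=C(N[C@H]1CN(C(=O)c2ccccc2)C[C@H]1NC(=O)c1ccc(Cl)s1)c1ccc(-n2ccccc2=O)cc1`) gives > 100000 nM as a limit too. The evidence so far is only this: the limit of > 100000 nM in this assay, at which 2 of the 2 values shown sit, and no readable number. Compound 3 (`CS(=O)(=O)N1C[C@H](NC(=O)c2ccc(-n3ccccc3=O)cc2)[C@H](NC(=O)c2ccc(Cl)s2)C1`) has methylsulfonyl in place of propanoyl on an amine nitrogen in a ring. Going by the values given here, the one measured step (a step that the two limits leave unreadable from compound 1 to compound 2) offers no size to carry over, so no step beyond the scatter is expected in this assay here. For compound 3 the estimated step (a number no higher from compound 1 to compound 3 (the limit leaves the size open)) stays within that expectation. Compound 3 is estimated at 100000 nM (expected range 50000 nM to 200000 nM).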

Compound 3, half-maximal inhibitory concentration: > 100000 nM
Compound 3: no number, only a limit (the forecaster's own chance of this, stated with the estimate: 90%); the middle value lies on the limit itself.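

In this assay, going by these compounds alone, compound 1, compound 2 and compound 3 each give only a limit, not a number, so no step among them can be read. From the compounds shown here alone, whether the group on the ring nitrogen affects this read-out at all stays open.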